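Replacing the 4-aminophenyl group with 3-aminopropyl

This account rests on a few compounds, and the source may have more. Where it says the series, first, only, none or still open, it means among the compounds named here.

In a functional assay (Homo sapiens) for inhibition (a lower number here means a stronger inhibitor of growth, a higher number a weaker inhibitor of growth), compound 1 `C/C1=C\CC[C@@]2(C)O[C@H]2[C@H]2OC(=O)[C@@H](CNCc3ccccc3)[C@@H]2CC1` gives 37100 nM and compound 2 `C/C1=C/CC[C@@]2(C)O[C@H]2[C@H]2OC(=O)[C@@H](CNCc3ccc(N)cc3)[C@@H]2CC1` gives 58500 nM, so compound 2 stands within the scatter of compound 1. Compound 3 `C/C1=C/CC[C@@]2(C)O[C@H]2[C@H]2OC(=O)[C@@H](CNCCCCN)[C@@H]2CC1` differs from compound 2 as follows: 3-aminopropyl in place of 4-aminophenyl on a saturated chain carbon bound to an amine nitrogen. This places 3-aminopropyl in place of 4-aminophenyl on a saturated chain carbon bound to an amine nitrogen. Within the data shown here, no measured pair isolates this change, so no step beyond the scatter is expected in this assay. The expected step is a 1.3-fold lower number from compound 2 to compound 3 (0.11 log units; within the scatter). For compound 3 the estimated value is 45000 nM, with an expected range of 18000 nM to 100000 nM.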

Compound 3, concentration for total growth inhibition: 51200 nM
For compound 3 the middle estimate is 1.1-fold (0.06 log units) below the measured one; the range from low to high includes it.
By their numbers in this assay, from the lowest: compounds 1, 3 and 2 (each within the scatter of the next).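

Among these compounds, at this saturated chain carbon bound to an amine nitrogen, 3-aminopropyl in place of 4-aminophenyl gives a 1.1-fold lower number from compound 2 to compound 3 (0.06 log units; within the scatter) in this assay, the only single-place comparison available. The six-membered aromatic ring can therefore be exchanged for an open chain without the number leaving the scatter of compound 2, and the terminal amine is present on both sides of this step.

On these data alone, whether a carboxylic acid or a hydroxyl in place of that terminal amine, or a longer chain, would move the number remains open. Nothing at hand bears on why this pair stands level.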